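Two nitrile chains replace a diethylamino tail on the amide

The compounds below may be only part of what the source reports. "The series", "measured", "known", "first", "only" and "open" are said of these compounds alone.

Measured compounds:
- compound 1, `CCn1c(C(=O)NCCN)ccc1C(CC)(CC)c1ccc(OCC(=O)C(C)(C)C)c(C)c1`, gives 1900 nM in a functional assay on Caco-2 cells (Homo sapiens), read by MTT assay, with a stated time of 48 h; on this read-out lower numbers stand for stronger inhibition and higher numbers for weaker inhibition
- compound 2, `CCN(CC)CCNC(=O)c1ccc(C(CC)(CC)c2ccc(OCC(O)C(C)(C)C)c(C)c2)n1CC`, gives 2310 nM in this assay
- compound 3, `CCn1c(C(=O)NCCCN(C)C)ccc1C(CC)(CC)c1ccc(OCC(O)C(C)(C)C)c(C)c1`, gives 1900 nM in this assay

All three compounds share the same core and differ only in the group attached to the amide carbonyl. Their numbers lie close together. Compound 2 shows the highest number of the three, yet its distance to compound 1 and its distance to compound 3 both fall within the usual scatter, so the three cannot really be separated.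

Compound 4, `CCn1c(C(=O)N(CCC#N)CCC#N)ccc1C(CC)(CC)c1ccc(OCC(O)C(C)(C)C)c(C)c1`, has not yet been measured. It is derived from compound 2 by the change (a group of 9 heavy atoms (6 carbon, 3 nitrogen; no ring) in place of a group of 8 heavy atoms (6 carbon, 2 nitrogen; no ring), on a carbonyl carbon). The amide hydrogen disappears, and two chains each ending in a nitrile take the place of the (2-(diethylamino)ethyl)amino group.

For the measured compounds named here, only one measured step touches this position: a 1.2-fold lower number from compound 2 to compound 3 (0.08 log units; within the scatter). That step swapped one amine for another and stayed within the scatter. Nothing measured removes the amine or introduces nitriles, so the step to compound 4 is largely uncharted.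

Given this, compound 4 is expected to land near its parent, with a step of a 1.3-fold higher number from compound 2 to compound 4 (0.11 log units; within the scatter) that need not exceed the scatter. The estimated value for compound 4 in this assay is 3000 nM, within a range from 1000 nM to 10000 nM.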

Compound 4, half-maximal inhibitory concentration: 7100 nM
For compound 4 the middle estimate is 2.4-fold (0.37 log units) below the measured one; low and high end bracket the measured number.
By their numbers in this assay, from the lowest: compounds 1, 3 and 2 (each within the scatter of the next); then compound 4.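

In this assay the earlier swap of one amine tail for another stayed within the scatter, so this position could have seemed to tolerate any change, but the two nitrile chains give a 3.1-fold higher number from compound 2 to compound 4 (0.49 log units; beyond the scatter) and also a 3.7-fold higher number from compound 3 to compound 4 (0.57 log units; beyond the scatter) so the group on the carbonyl carbon does matter for this read-out. Both steps are modest but beyond the scatter, and they point the same way, towards weaker inhibition, whichever amine-bearing compound serves as the starting point. The change does several things at once, since the amide hydrogen goes, the amine goes and two nitriles arrive, and no measurement at hand explains the loss or ties it to any one of these parts.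

The compounds shown leave open which part counts, and an amide that keeps its hydrogen and carries a single 2-cyanoethyl chain, or an amide nitrogen carrying two plain propyl chains, would begin to separate the three. On these data alone, it also remains open whether a longer amine chain, or a carboxylic acid at the end of the tail, would stay level with compound 2 or move away from it.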